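Fluoro to Methoxy: What Size of Step to Expect

The compounds below may be only part of what the source reports. "The series", "measured", "known", "first", "only" and "open" are said of these compounds alone.

In a functional assay on B16-F10 cells (Mus musculus) for antiproliferative activity, read by MTT assay, with a stated time of 48 h (on this read-out higher numbers stand for weaker inhibition and lower numbers for stronger inhibition), compound 1 (`Cc1ccc(-c2cc(NC(=O)/C=C/c3ccc(Cl)cc3)n[nH]2)cc1`) gives 1520 nM and compound 2 (`Cc1ccc(-c2cc(NC(=O)/C=C/c3ccc(F)cc3)n[nH]2)cc1`) gives 1430 nM as its reading, level with compound 1. Compound 3 (`COc1ccc(/C=C/C(=O)Nc2cc(-c3ccc(C)cc3)[nH]n2)cc1`) carries methoxy in place of fluoro on an aromatic carbon. For the measured compounds named here, the one measured step that bears on this, fluoro in place of chloro, gave a 1.1-fold lower number from compound 1 to compound 2 (0.03 log units; within the scatter) and so stayed within the scatter. Neither measured compound carries methoxy, which makes this a thin guide. No step beyond the scatter is expected in this assay and the estimate is a 1.0-fold higher number from compound 2 to compound 3 (0.02 log units; within the scatter) for this change. Compound 3 is expected to read 1500 nM (estimated range 600 nM to 3800 nM).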

Compound 3, half-maximal inhibitory concentration: 1370 nM
Beside the measured number, compound 3's estimate is 1.1-fold (0.04 log units) above it; the measured number falls inside the stated range.
By their numbers in this assay, from the lowest: compounds 3, 2 and 1 (each within the scatter of the next).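

In this assay, going from 4-fluorophenyl to 4-methoxyphenyl gives a 1.0-fold lower number from compound 2 to compound 3 (0.02 log units; within the scatter) even though the entering group has 2 heavy atoms and 1 hydrogen-bond acceptor. Methoxy in place of chloro likewise gives a 1.1-fold lower number from compound 1 to compound 3 (0.05 log units; within the scatter) at this aromatic carbon, so chloro, fluoro and methoxy all read level here, which the halogen pair alone could not show. No measurement here explains this level reading. On these data alone, whether an amine, a carboxylic acid or a longer chain such as butoxy would also read level at this position remains open.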